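Hydroxy for fluoro on the aryl of a pyrazine hydrazone

The source may hold more compounds than are shown below. What is called first, only, known or untested is meant among the compounds shown, and "the series" means these compounds.

Compound 1: `O=C(N/N=C/c1ccc(F)cc1)c1cnccn1` — 71%
Compound 2: `O=C(N/N=C/c1cccc(Br)c1)c1cnccn1` — 93%
Compound 3: `O=C(N/N=C/c1ccccc1O)c1cnccn1` — 0%

Of the compounds shown here, three sharing one core have been measured in an ADME assay on J774 cells (Mus musculus) for cytotoxicity, read by MTT assay, with a stated time of 48 h, tested at 150 ug/mL; a higher number here means a weaker effect of the compound at the concentration tested, a lower number a stronger effect. Compound 1 gives 71%, the second highest of the three numbers. Its nearest neighbour is compound 2, whose 93% lies beyond the scatter above it; the furthest is compound 3, whose 0% lies far below, also beyond the scatter. Among the measured compounds shown here, compound 3 is the one member that carries a hydroxy on the aryl ring.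

Not yet measured is compound 4, `O=C(N/N=C/c1ccc(O)cc1)c1cnccn1`. It differs from compound 1 by hydroxy in place of fluoro on an aromatic carbon, para to a large group. For the measured compounds named here, no step between measured compounds matches this change, so there is no direct precedent. Since compound 3, the other hydroxy-bearing member, gives 0%, a step downward beyond the scatter is expected from compound 1 to compound 4, though with wide uncertainty. For compound 4 the expected value in this assay is 45%, with a range from 15% to 80%, amounting to an estimated step of a number 26 percentage points lower from compound 1 to compound 4 (beyond the scatter).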

Compound 4, a percentage reported as activity, at one concentration (the size of the read-out at that concentration, not a potency): 80%
The estimate for compound 4 lay 35 percentage points below the measured number; measured number inside the range.
By their numbers in this assay, from the lowest: compound 3; then compounds 1 and 4 (each within the scatter of the next); then compound 2.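

In this assay, hydroxy in place of fluoro on an aromatic carbon, para to a large group, amounts to a number 9 percentage points higher from compound 1 to compound 4 (within the scatter) and so leaves the two compounds indistinguishable at this position. A hydroxy on the aryl ring therefore does not by itself go with a low number: compound 4 carries one and gives 80% here, while compound 3, which also carries one, gives 0% on the same read-out. Nothing shown accounts for the difference between these two hydroxy-bearing compounds.

From the compounds shown here alone, whether an amine, a methoxy or a carboxylic acid on this same carbon would also stay level with compound 1 remains open. It is also open what the low number of compound 3 depends on, as no step to that compound can be read from the compounds shown.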